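Three Fused Bicyclic Amines and a Chain Extension Still to Test

The compounds below may be only part of what the source reports. "The series", "measured", "known", "first", "only" and "open" are said of these compounds alone.

The set holds three measured compounds that share a fused bicyclic core. Compound 1 `Cc1nc2c(COc3ccccc3)cccn2c1N`, compound 2 `Cc1ccn2c(N)c(C)nc2c1OCc1ccccc1` and compound 3 `Cc1nc2c(OCc3ccccc3)cccn2c1CN` were each tested in a functional assay on the whole organism with Rattus norvegicus as the target, at a dose of 40 mg/kg by the intraperitoneal route; on this read-out lower numbers stand for less inhibition and higher numbers for more inhibition at the one dose given (going by the name of the read-out). In this assay compound 1 gives 27%, compound 2 gives 60% and compound 3 gives 46%. On these numbers compound 3 stands second highest of the three: its nearest neighbour is compound 2, whose number lies higher by a margin beyond the scatter, and its furthest is compound 1, whose number lies lower by a margin also beyond the scatter. Within the data shown here, no two of the measured compounds differ in only one place, so no step between them can be read directly.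

The next compound, compound 4 `CCCNc1c(C)nc2c(OCc3ccccc3)cccn12`, differs from compound 3 in a single position: propylamino in place of aminomethyl on an aromatic carbon. Among the measured compounds shown here, with no measured pair covering a change of this kind, the direction of the step is open; a move within the scatter, in either direction, is as plausible as any other. Compound 4 is therefore expected to give 45% in this assay, within a range from 20% to 70%. That estimate for compound 4 means a step of a number 1 percentage points lower from compound 3 to compound 4 (within the scatter), which is not expected to reach beyond the scatter.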

Compound 4, a percentage reported as inhibition, in the whole organism at one dose (the size of the read-out at that dose, not a potency): 99%
Compound 4: middle estimate off by 54 percentage points, on the low side, outside the stated range (above it).
By their numbers in this assay, from the lowest: compound 1; then compound 3; then compound 2; then compound 4.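

In this assay, among these compounds, this position on the five-membered aromatic ring proves highly sensitive to the group it carries: putting propylamino in place of aminomethyl gives a number 53 percentage points higher from compound 3 to compound 4 (beyond the scatter) and so provides the first step in the set that can be read between compounds differing in one place. The leaving and entering groups have the same count of hydrogen-bond donors and acceptors and neither carries a net charge, so the step comes with no change in those counts, while the heavy atoms of the group rise from 2 to 4. Nothing available here accounts for the size of the step.

Aminomethyl and propylamino differ in more than one feature, so the compounds shown do not separate the length of the carbon chain from the way the nitrogen is joined to the ring, a question that a simple amino, methylamino, ethylamino or butylamino group at this place would bear on. On these data alone, whether propylamino would give a step of similar size on the cores of compound 1 or compound 2 also remains open.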